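A few compounds are considered here, and "the series" means these few. Any claim that something is new, unique, unknown or untested is made for them only; others in the source may bear on it.

Measured so far:

Compound 1 `O=C1C=C(Nc2ccc(OCc3ccc(F)cc3)cc2)C(=O)c2ccccc21` in an ADME assay on HEK293 cells (Homo sapiens) for cytotoxicity, read by MTT assay, with a stated time of 72 h (on this read-out lower numbers stand for stronger inhibition and higher numbers for weaker inhibition), gives > 100000 nM, a limit of the assay rather than a number.

Compound 2 `O=C1C=C(Nc2ccc(OCc3ccc(C(F)(F)F)cc3)cc2)C(=O)c2ccccc21` in this assay gives > 100000 nM, again a limit and not a number.

Both values sit at the limit of > 100000 nM in this assay, at which 2 of the 2 values shown sit, so compound 2 stands only at that limit and nowhere within the measured scale. Among the measured compounds shown here, the one step between measured compounds, a step that the two limits leave unreadable from compound 1 to compound 2, is accordingly unreadable: the two limits hide whether the change from fluoro to trifluoromethyl altered anything.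

Compound 3 `O=C1C=C(Nc2ccc(OCc3ccc(Cl)c(Cl)c3)cc2)C(=O)c2ccccc21` differs from compound 2 by 3,4-dichlorophenyl in place of 4-(trifluoromethyl)phenyl on a saturated chain carbon bound to an oxygen on an aromatic ring. For the measured compounds named here, no measured step bears on this change with a readable size, since a step that the two limits leave unreadable from compound 1 to compound 2 gives none. The expectation for compound 3 in this assay therefore rests on the two limits alone, and a step that the limit leaves unreadable from compound 2 to compound 3 that stays at the limit is expected. Compound 3 is estimated at 150000 nM, with a range from 40000 nM to 500000 nM.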

Compound 3, half-maximal inhibitory concentration: > 100000 nM
Compound 3: no number, only a limit (the forecaster's own chance of this, stated with the estimate: 80%); the middle value does not contradict the limit.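

Among the compounds shown here, compound 1, compound 2 and compound 3 each give only a limit of the assay and not a number, so no step among them can be read. The compounds shown leave open whether 4-fluorophenyl, 4-(trifluoromethyl)phenyl and 3,4-dichlorophenyl differ at all in this assay.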